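A few compounds are considered here, and "the series" means these few. Any claim that something is new, unique, unknown or untested is made for them only; others in the source may bear on it.

Compound 1 `COC[C@@H]1CCCN1C(=O)C1CCCN1c1cc(Nc2cccc(Br)c2)ncn1`: 0%
Compound 2 `COC(=O)C(CO)NC(=O)[C@@H]1CCCN1c1nccc(Oc2cccc(C)c2)n1`: 0%
Compound 3 `Cc1cccc(N(C)c2cc(Nc3cccc(C(=O)N4CCCC5CCCCC54)c3)ncn2)c1`: 0%

In an assay on isolated protein for inhibition of calcium/calmodulin-dependent protein kinase type IV (Homo sapiens), read by HTRF, tested at 10 uM (a higher number here means more inhibition at the concentration tested (going by the name of the read-out), a lower number less inhibition), compound 3 gives 0%, level with compound 1 and with compound 2 at the digits shown, all within the usual scatter, so none of the three shows any inhibition at the concentration tested. Compound 4 `Cc1cccc(N(C)c2cc(Nc3cccc(C(=O)N(CC(C)C)CC(C)C)c3)ncn2)c1` has not yet been measured. It differs from compound 3 in one place: a group of 9 heavy atoms (8 carbon, 1 nitrogen; no ring) in place of a group of 10 heavy atoms (9 carbon, 1 nitrogen; one six-membered non-aromatic ring of carbon only, one six-membered non-aromatic ring with 1 hetero atom), on a carbonyl carbon. The ring-bearing group on the carbonyl carbon gives way to a diisobutylamino group. Among the compounds with values here, no measured pair shows what such a swap does, and the three measured compounds all sit at the same low level, so there is no trend to build on. The step of no change at the digits printed from compound 3 to compound 4 (within the scatter) is expected to stay within the scatter. Compound 4 is therefore expected to give 0% in this assay, with a likely range from -10% to 12%.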

Compound 4, a percentage reported as inhibition, at one concentration (the size of the read-out at that concentration, not a potency): 0%
For compound 4 middle estimate and measured number coincide at the digits printed, within the range that was stated.
By their numbers in this assay, from the lowest: compounds 1, 2, 3 and 4 (each within the scatter of the next).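

In this assay, within the data shown here, the swap of the ring-bearing group on the carbonyl carbon for diisobutylamino gives no change at the digits printed from compound 3 to compound 4 (within the scatter) and provides the first direct comparison at this place. Removing both six-membered rings brings out no inhibition here, but with both compounds reading nothing, the pair cannot show whether this group matters at all. No available evidence bears on this result. Still open, on these data alone, is whether a piperazine or a carboxylic acid on this carbonyl carbon would give any inhibition. A change to the shared core might also do so.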